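The source may report more compounds than this note shows. Statements on the series, on what has been measured and on what is new or still open speak of the compounds shown alone.

In a functional assay on A549 cells (Homo sapiens) for inhibition, read by CCK-8 assay, with a stated time of 48 h (a higher number here means a weaker inhibitor, a lower number a stronger inhibitor), compound 3 `COc1cc(-c2ccnc3cc(-c4ccc(C)c(C)c4)nn23)cc(OC)c1OC` gives 272 nM, the lowest of the two plain numbers shown. The nearest neighbour is compound 2 `Cn1ccc2cc(-c3cc4nccc(-c5ccc(F)cc5)n4n3)ccc21`, which in this assay gives 3520 nM, a gap that lies beyond the usual scatter. Compound 1 `COc1cc(-c2cc3nccc(-c4c[nH]c5ccccc45)n3n2)cc(OC)c1OC` reaches only a limit of the assay, > 10000 nM, so no number is known for it; this is the case described by the limit of > 10000 nM in this assay, at which 1 of the 3 values shown sits.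

The step now considered leads from compound 3 to compound 4 `COc1cc(-c2ccnc3cc(-c4ccc5ccn(C)c5c4)nn23)cc(OC)c1OC`, a change at one aromatic carbon of the shared core: 1-methyl-1H-indol-6-yl in place of 3,4-dimethylphenyl on an aromatic carbon. No step between two measured compounds is shown, so the size of this change can only be expected, not read off. Compound 2 gives 3520 nM with a different pattern of substitution, and compound 4 is expected to fall between it and compound 3. The step of a 2.9-fold higher number from compound 3 to compound 4 (0.47 log units; beyond the scatter) is expected to point toward a weaker inhibitor. For compound 4 the expected value in this assay is 800 nM, within a range from 250 nM to 3000 nM.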

Compound 4, half-maximal inhibitory concentration: 829 nM
For compound 4 the middle estimate is 1.0-fold (0.02 log units) below the measured one; the measured number falls inside the stated range.
By their numbers in this assay, from the lowest: compound 3; then compound 4; then compound 2. At a limit, above all of these: compound 1.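

In this assay, among these compounds, replacing 3,4-dimethylphenyl with 1-methyl-1H-indol-6-yl gives a 3.0-fold higher number from compound 3 to compound 4 (0.48 log units; beyond the scatter) at this position, the first direct reading of a change here on the shared core. The larger group with two rings still leaves compound 4 with a plain number, so this aromatic carbon of the five-membered ring accepts it at a modest cost, though it does not match the single ring of 3,4-dimethylphenyl. Nothing measured here says why the step runs in this direction.

Open, from the compounds shown here alone, is how a pyridine ring, or a phenyl ring carrying an amine, would fare at this same carbon. Also open, going by these compounds, is whether each methyl group of 3,4-dimethylphenyl matters on its own, and whether the methyl on the indole nitrogen matters in compound 4.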